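A few compounds are considered here, and "the series" means these few. Any claim that something is new, unique, unknown or untested is made for them only; others in the source may bear on it.

Compound 1 `Nc1cc(-c2ccccc2)ccc1Cn1cncc1CNc1ccc(Cl)c(-c2ccccc2)c1` gives > 1000 nM in a toxicity assay on NIH3T3 cells (Mus musculus) for cytotoxicity, read by resazurin assay; a lower number here means that less compound is needed, a higher number that more compound is needed for the effect.
Compound 2 `O=C(OC1CCCCC1)c1ccc(NCc2cncn2Cc2ccc(-c3ccccc3)cc2)cc1-c1ccccc1` gives > 10000 nM in this assay.
Compound 3 `COC(=O)c1ccc(NCc2cncn2Cc2cccc(-c3ccccc3)c2)cc1-c1ccccc1` gives "not determined" (no result reported) in this assay.

Of the three compounds of this series, two come with a limit only and one without any result. For compound 2 the reading is a limit of the assay and not a number, as the limit of > 10000 nM in this assay, at which 1 of the 3 values shown sits, shows. For compound 1 the reading is likewise a limit, as the limit of > 1000 nM in this assay, at which 1 of the 3 values shown sits, shows. Compound 3 has no result reported in this assay. Among the measured compounds shown here, compound 2 therefore stands nowhere in an order: no step between measured compounds can be drawn, and nothing in these numbers sets it apart from compound 1.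

Compound 4 `c1ccc(-c2ccc(Cn3cncc3CNc3ccc(-c4cc5ccccc5o4)c(-c4ccccc4)c3)cc2)cc1` is not yet measured. It differs from compound 2 in one place: 1-benzofuran-2-yl in place of cyclohexyloxycarbonyl on an aromatic carbon. A 1-benzofuran-2-yl thus takes the place of the cyclohexyloxycarbonyl on an aromatic carbon, ortho to a phenyl group and para to a large group.

With both measured values sitting at limits, the expected step that the limit leaves unreadable from compound 2 to compound 4 is none beyond the scatter, and compound 4 is most likely to come back as a limit as well. Compound 4 is estimated at 20000 nM, with a range from 5000 nM to 80000 nM.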

Compound 4, half-maximal effective concentration: > 10000 nM
Compound 4: no number, only a limit; the forecaster's own chance of this, stated with the estimate: 80%; the middle value is on the limit's open side.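

In this assay compound 4 gives > 10000 nM, which is a limit of the assay and not a number. Among the compounds shown here, compound 2 also stands at a limit, so no step between compound 2 and compound 4 can be read. The compounds shown leave open whether 1-benzofuran-2-yl in place of cyclohexyloxycarbonyl shifts the reading in this assay at all.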